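The source may hold more compounds than are shown below. What is called first, only, known or untested is meant among the compounds shown, and "the series" means these compounds.

Working notes on the series, read in a functional assay on K562 cells (Homo sapiens) for cytotoxicity, read by MTT assay, with a stated time of 3 days; a lower number here means a stronger inhibitor, a higher number a weaker inhibitor. Compound 1 `N#Cc1c(NN)nc(SCc2nc3ccccc3[nH]2)nc1-c1ccccc1` gives 14.7 nM, compound 2 `CNc1nc(SCc2nc3ccccc3[nH]2)nc(-c2ccccc2)c1C#N` gives 13.2 nM and compound 3 `CCNc1nc(SCc2nc3ccccc3[nH]2)nc(-c2ccccc2)c1C#N` gives 4.38 nM. The first two of these are not separated: a 1.1-fold lower number from compound 1 to compound 2 (0.05 log units; within the scatter). Compound 2 therefore stands level with compound 1 at the upper end of the three numbers, and the gap to the lowest number is a 3.0-fold lower number from compound 2 to compound 3 (0.48 log units; beyond the scatter).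

The next compound is compound 4 `N#Cc1c(NC(N)=S)nc(SCc2nc3ccccc3[nH]2)nc1-c1ccccc1`. The change is a group of 3 heavy atoms (1 carbon, 1 nitrogen, 1 sulfur; no ring) in place of one carbon atom, on a nitrogen on an aromatic ring.

All three measured steps fall at this same nitrogen, so all of them bear on the change. The widest is a 3.4-fold lower number from compound 1 to compound 3 (0.53 log units; beyond the scatter), which is only modest. Among the compounds with values here, none of the measured compounds carries the entering group, so the data give no direct precedent and no firm direction. The estimated step is a 1.2-fold higher number from compound 2 to compound 4 (0.08 log units; within the scatter), so no change beyond the scatter is expected. For compound 4 the estimated value is 16 nM, with an expected range of 5 nM to 50 nM.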

Compound 4, half-maximal inhibitory concentration: 11.9 nM
Compound 4: the middle estimate sits 1.3-fold (0.13 log units) above what was measured; the measured number falls inside the stated range.
By their numbers in this assay, from the lowest: compound 3; then compounds 4, 2 and 1 (each within the scatter of the next).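

In this assay, this nitrogen on an aromatic ring takes the group of 3 heavy atoms (1 carbon, 1 nitrogen, 1 sulfur), with its 1 hydrogen-bond donor and 1 hydrogen-bond acceptor, with no shift beyond the scatter from the smaller groups: a 1.1-fold lower number from compound 2 to compound 4 (0.05 log units; within the scatter), and a 1.2-fold lower number from compound 1 to compound 4 (0.09 log units; within the scatter). Heavy-atom count alone therefore does not order the series, since compound 3, with its ethyl group, remains apart from this larger group, at a 2.7-fold higher number from compound 3 to compound 4 (0.43 log units; beyond the scatter), while compound 4 stays level with compound 2, which carries only a methyl group, and these two compounds go against any simple trend with group size. Nothing measured on these compounds accounts for the separate position of compound 3 or for the level position of compound 4.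

Still open, on these data alone, is whether the ethyl result extends to a propyl chain, a longer chain or a cyclopropyl ring on this nitrogen. A urea group, with oxygen in place of the sulfur, would test whether the sulfur matters to the number seen for compound 4.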